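Cyclopropyl in Place of Vinyl on the Amide Carbonyl

The source may report more compounds than this note shows. Statements on the series, on what has been measured and on what is new or still open speak of the compounds shown alone.

Among the measured compounds shown here, compound 3 `C=CC(=O)N(Cc1ccc(OC)c(O)c1)c1cc(OC)c(OC)c(OC)c1` gives 62 nM in a functional assay on MGC-803 cells (Homo sapiens) for inhibition, read by MTT assay, with a stated time of 48 h (a higher number here means a weaker inhibitor, a lower number a stronger inhibitor), and holds the second highest of the three numbers so far; its nearest neighbour is compound 2 `CCC(=O)N(Cc1ccc(OC)c(O)c1)c1cc(OC)c(OC)c(OC)c1`, which gives 50 nM, and the furthest is compound 1 `C/C=C/C=C/C(=O)N(Cc1ccc(OC)c(O)c1)c1cc(OC)c(OC)c(OC)c1`, which gives 140 nM. Compound 4 `COc1ccc(CN(C(=O)C2CC2)c2cc(OC)c(OC)c(OC)c2)cc1O` differs from compound 3 by cyclopropyl in place of vinyl on a carbonyl carbon. For the measured compounds named here, the steps that bear on this are a 1.2-fold higher number from compound 2 to compound 3 (0.09 log units; within the scatter), a 2.3-fold lower number from compound 1 to compound 3 (0.35 log units; beyond the scatter) and a 2.8-fold lower number from compound 1 to compound 2 (0.45 log units; beyond the scatter): ethyl and vinyl on the carbonyl carbon sit together, and only penta-1,3-dien-1-yl gives a higher number. Cyclopropyl is judged nearer to ethyl and vinyl than to penta-1,3-dien-1-yl, so for compound 4 a step of a 1.0-fold higher number from compound 3 to compound 4 (0.02 log units; within the scatter) is expected, within the scatter. The estimate for compound 4 is 65 nM, with a range of 30 nM to 140 nM.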

Compound 4, half-maximal inhibitory concentration: 59 nM
Compound 4: middle estimate off by 1.1-fold (0.04 log units), on the high side; the measured number falls inside the stated range.
By their numbers in this assay, from the lowest: compounds 2, 4 and 3 (each within the scatter of the next); then compound 1.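

A three-membered ring on the carbonyl carbon sits with vinyl and ethyl in this assay: a 1.1-fold lower number from compound 3 to compound 4 (0.02 log units; within the scatter) and a 1.2-fold higher number from compound 2 to compound 4 (0.07 log units; within the scatter), both within the scatter. Against penta-1,3-dien-1-yl, cyclopropyl shows a 2.4-fold lower number from compound 1 to compound 4 (0.38 log units; beyond the scatter), beyond the scatter, so among the four groups shown only penta-1,3-dien-1-yl stands apart. No measured evidence accounts for these steps.

Open, as far as these compounds go, is whether a larger ring such as cyclohexyl or a longer chain such as butyl stays with the three close groups or parts from them as penta-1,3-dien-1-yl does. From the compounds shown here alone, an amine or a carboxylic acid carried on this carbonyl carbon's substituent is equally open.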